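This account rests on a few compounds, and the source may have more. Where it says the series, first, only, none or still open, it means among the compounds named here.

Compound 1, `CNC(=O)c1ccc(C(=O)C2=C(O)C(=O)N(c3ccc(-c4ccon4)cc3)C2C2CCCCC2)cc1`, was tested in an ADME assay on the whole organism (serum, Rattus norvegicus) for protein binding (a higher number here means a larger unbound share of the compound, a lower number a smaller unbound share), and compound 1 gives 0.007, so only a very small share of it is free in serum. Compound 2, `Cc1nc(-c2ccc(N3C(=O)C(O)=C(C(=O)C(C)(C)C)C3c3ccccc3OCCO)cc2)no1`, shares the same core; in this assay compound 2 gives "not determined" (no result reported), so there is no single number for it in this assay. Compound 3, `CC(C)(C)C(=O)C1=C(O)C(=O)N(c2ccc(-c3cccs3)cc2)C1c1ccccc1OCCO`, differs from compound 2 by thiophen-2-yl in place of 5-methyl-1,2,4-oxadiazol-3-yl on an aromatic carbon. Within the data shown here, with no measured step at hand, the change is expected to shift the unbound share downward, possibly beyond the usual scatter. Compound 3 is estimated at 0.005, within a range of 0.002 to 0.015.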

Compound 3, unbound fraction: 0.001
Compound 3: middle estimate off by 5.0-fold (0.70 log units), on the high side; measured number below the stated range.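

Among these compounds, compound 2 has no number in this assay, so no step from it to compound 3 can be read. Nothing shown here accounts for the result of compound 3. Still open, from the compounds shown here alone, is whether thiophen-2-yl in place of 5-methyl-1,2,4-oxadiazol-3-yl shifts the result in this assay at all.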